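Swapping the aryl ether for an aryl thioether on a shared core

This account rests on a few compounds, and the source may have more. Where it says the series, first, only, none or still open, it means among the compounds named here.

Compound 1 `Nc1cc(N)c2nc(-c3ccccc3)c(Oc3ccc(Cl)c(Cl)c3)nc2c1`: 70800 nM
Compound 2 `Nc1cc(N)c2nc(-c3ccccc3)c(NCc3ccc(Cl)c(Cl)c3)nc2c1`: 46800 nM
Compound 3 `CCOC(=O)[C@H](CCC(=O)O)NC(=O)c1ccc(Sc2nc3cc(N)cc(N)c3nc2-c2ccccc2)cc1`: < 100000 nM

Of the compounds shown here, three sharing one core have been tested in a functional assay on NCI-H460 cells (Homo sapiens) for inhibition, read by sulforhodamine B assay, with a stated time of 48 h; on this read-out lower numbers stand for stronger inhibition of growth and higher numbers for weaker inhibition of growth. Compound 1 gives 70800 nM, the highest of the two plain numbers, and compound 2 gives 46800 nM, the nearest value and within the scatter of compound 1, so the two cannot be told apart. For compound 3 the result is a limit of the assay rather than a number, < 100000 nM, and this is the only limit among the three values (the limit of < 100000 nM in this assay, at which 1 of the 3 values shown sits).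

Compound 4 `Nc1cc(N)c2nc(-c3ccccc3)c(Sc3ccc(F)cc3)nc2c1` has not yet been measured in this assay. It differs from compound 1 in one place: (4-fluorophenyl)sulfanyl in place of 3,4-dichlorophenoxy on an aromatic carbon.

Among the compounds with values here, nothing measured here speaks directly to the effect of this change, since no pair of measured compounds differs in only one group. The two plain numbers lie close together and all three compounds are weak, so the step from compound 1 to compound 4 is expected to be small, at most a little toward stronger inhibition of growth, a 1.4-fold lower number from compound 1 to compound 4 (0.15 log units; within the scatter). For compound 4 the estimated value is 50000 nM, with an expected range from 15000 nM to 150000 nM.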

Compound 4, concentration for total growth inhibition: 66100 nM
For compound 4 the middle estimate is 1.3-fold (0.12 log units) below the measured one; the range from low to high includes it.
By their numbers in this assay, from the lowest: compounds 2, 4 and 1 (each within the scatter of the next).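

In this assay the exchange of 3,4-dichlorophenoxy for (4-fluorophenyl)sulfanyl on this aromatic carbon, next to the ring nitrogen, gives a 1.1-fold lower number from compound 1 to compound 4 (0.03 log units; within the scatter) and so leaves no difference that can be told from the scatter. Within the data shown here, this is the first comparison in which only one group differs, and it shows that this position accepts a change of the linking atom from oxygen to sulfur, together with a change of the ring's halogens from two chlorine atoms to one fluorine, without any clear shift in the read-out. As both changes come in a single step, their separate contributions cannot be read, and they could be small or could offset each other, while nothing measured here accounts for how little the number moves.

Still open, on these data alone, is how this position responds when the aromatic ring is replaced altogether, for example by a simple amine, a carboxylic acid or a longer alkyl chain. Also open, as far as these compounds go, is whether 4-fluorophenoxy or (3,4-dichlorophenyl)sulfanyl would separate the effect of the linking atom from that of the halogens.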